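The source may hold more compounds than are shown below. What is called first, only, known or untested is meant among the compounds shown, and "the series" means these compounds.

Measured compounds:
compound 1, `O=C(CCC(=O)OCCCCCCSc1ccc([N+](=O)[O-])c2nonc12)Nc1ccccc1`: 10200 nM
compound 2, `Cc1ccc(NC(=O)CCC(=O)OCCCCCCSc2ccc([N+](=O)[O-])c3nonc23)cc1`: 6800 nM
compound 3, `COc1ccc(NC(=O)CCC(=O)OCCCCCCSc2ccc([N+](=O)[O-])c3nonc23)cc1OC`: 6470 nM

Three compounds with a shared core were tested in an assay on isolated protein for inhibition of glutathione S-transferase P (Homo sapiens), with a stated time of 10 min; a higher number here means a weaker inhibitor, a lower number a stronger inhibitor. Compound 1 gives 10200 nM, compound 2 gives 6800 nM and compound 3 gives 6470 nM. Compound 3 holds the lowest of the three numbers, yet no separation beyond the scatter exists among them: the steps of a 1.5-fold lower number from compound 1 to compound 2 (0.18 log units; within the scatter), a 1.6-fold lower number from compound 1 to compound 3 (0.20 log units; within the scatter) and a 1.1-fold lower number from compound 2 to compound 3 (0.02 log units; within the scatter) all stay within the usual spread of repeated measurements.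

Compound 4, `O=C(CCC(=O)N1CCCCC1)OCCCCCCSc1ccc([N+](=O)[O-])c2nonc12`, has not yet been measured. It differs from compound 3 by piperidin-1-yl in place of (3,4-dimethoxyphenyl)amino on a carbonyl carbon. The measured steps bear on this change only loosely, since each of them altered substituents on the aromatic ring attached to the amide nitrogen while keeping that ring and the amide hydrogen; none of them removed the ring as the change to compound 4 does. Every one of those steps was within the scatter. The data give no sign that this part of the molecule moves the number strongly; the change here, however, is larger than any tested, and a wide range is warranted. Compound 4 is expected to give about 9000 nM, in a range of 3500 nM to 25000 nM. The estimated step of a 1.4-fold higher number from compound 3 to compound 4 (0.14 log units; within the scatter) is expected to be small, possibly toward a somewhat higher number.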

Compound 4, half-maximal inhibitory concentration: 500 nM
The estimate for compound 4 lay 18-fold (1.26 log units) above the measured number; measured number below the stated range.
By their numbers in this assay, from the lowest: compound 4; then compounds 3, 2 and 1 (each within the scatter of the next).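

In this assay, among these compounds, the position on the carbonyl carbon proves far more responsive than the earlier compounds suggested: piperidin-1-yl in place of the arylamino group gives a 13-fold lower number from compound 3 to compound 4 (1.11 log units; beyond the scatter) and a 14-fold lower number from compound 2 to compound 4 (1.13 log units; beyond the scatter) and also a 20-fold lower number from compound 1 to compound 4 (1.31 log units; beyond the scatter), each beyond the scatter. Among compounds 1, 2 and 3, changes to substituents on the aromatic ring left the number within the scatter, whereas this exchange of the whole group, which removes both the aromatic ring and the amide hydrogen, separates compound 4 clearly from all three. No supporting evidence is available to explain this gain in inhibition.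

The compounds shown leave open whether the aromatic ring, the amide hydrogen or the two together account for the step, as all of these change at once in compound 4. Cyclohexylamino, which keeps the amide hydrogen on a non-aromatic ring, N-methylanilino, which keeps the aromatic ring without that hydrogen, and morpholin-4-yl, which adds an oxygen to the ring of compound 4, lie outside this set and would help to separate these possibilities.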